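This account rests on a few compounds, and the source may have more. Where it says the series, first, only, none or still open, it means among the compounds named here.

Working notes on the cytotoxicity series.

Compound 1 `CCC1(Cc2ccccc2)OS(=O)(=O)C=C1OCc1ccc(C)cc1` carries a methyl on the aromatic ring of its benzyl ether. In an ADME assay on HEL cells (Homo sapiens) for cytotoxicity, with a stated time of 3 days (a higher number here means that more compound is tolerated, a lower number that less compound is tolerated), compound 1 gives >= 16000 nM, which is a limit of the assay and not a number. Compound 2 `CCC1(Cc2ccccc2)OS(=O)(=O)C=C1OCc1ccc(F)cc1` has fluoro in place of methyl on that aromatic carbon. In this assay compound 2 gives >= 50000 nM, again a limit rather than a measured number. The step that the two limits leave unreadable from compound 1 to compound 2 therefore cannot be sized: one value sits at the limit of >= 16000 nM in this assay, at which 1 of the 2 values shown sits, and the other at the limit of >= 50000 nM in this assay, at which 1 of the 2 values shown sits, so compound 2 stands only as a limit, with no figure that a further change could be read against.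

Compound 3 `CCC1(Cc2ccccc2)OS(=O)(=O)C=C1OCc1ccc(C(F)(F)F)cc1` is not yet measured. It differs from compound 2 by trifluoromethyl in place of fluoro on an aromatic carbon. Within the data shown here, the one measured step, from compound 1 to compound 2, bears on it only as two limits, so no direction beyond the scatter is expected in this assay. Compound 3 is estimated at 50000 nM, expected between 16000 nM and 100000 nM, which means an expected step of a number no higher from compound 2 to compound 3 (the limit leaves the size open); a further limit rather than a number is the likelier outcome.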

Compound 3, minimum cytotoxic concentration: >= 16000 nM
Compound 3: only a limit was reported (the forecaster's own chance of this, stated with the estimate: 75%); the middle value lies beyond the limit too.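

In this assay, among these compounds, compound 3 gives >= 16000 nM, a limit of the assay and not a number, so no step from compound 1 or compound 2 to compound 3 can be read. The compounds shown leave open whether methyl, fluoro and trifluoromethyl on this aromatic carbon differ at all in minimum cytotoxic concentration.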